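The source may hold more compounds than are shown below. What is called first, only, known or untested is meant among the compounds shown, and "the series" means these compounds.

Compound 1 `CC(=O)OC/C(=C\c1ccc(Cl)cc1Cl)C(=O)c1ccccc1` gives 9500 nM in a functional assay on T47D cells (Homo sapiens) for inhibition, read by sulforhodamine B assay, with a stated time of 48 h; a lower number here means a stronger inhibitor of growth, a higher number a weaker inhibitor of growth. Compound 2 `O=C(OC/C(=C\c1ccc(Cl)cc1Cl)C(=O)c1ccccc1)c1ccccc1`, which carries a phenyl in place of a methyl on the carbonyl carbon of the ester, gives 17000 nM in this assay, and the change from compound 1 to compound 2 was a 1.8-fold higher number from compound 1 to compound 2 (0.25 log units; within the scatter). Compound 3 `CC(=O)OC/C(=C/c1ccc(Cl)cc1Cl)C(=O)c1ccccc1` gives 20000 nM in this assay, and the change from compound 1 to compound 3 was a 2.1-fold higher number from compound 1 to compound 3 (0.32 log units; beyond the scatter), a step that rests only on (the fact that compounds 1 and 3 differ only in the configuration as drawn). Compound 3 thus stands at the upper end of the three numbers, though its gap to compound 2 lies within the scatter. Compound 4 `O=C(OC/C(=C/c1ccc(Cl)cc1Cl)C(=O)c1ccccc1)c1ccccc1` has not yet been measured. It differs from compound 3 by phenyl in place of methyl on a carbonyl carbon. For the measured compounds named here, the one precedent for this exact change is the step from compound 1 to compound 2, which was within the usual scatter. The step in this assay is therefore expected to be small, estimated as a 1.5-fold higher number from compound 3 to compound 4 (0.18 log units; within the scatter). Compound 4 is expected to give about 30000 nM in this assay, most likely between 13000 nM and 70000 nM.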

Compound 4, concentration for 50% growth inhibition: 5400 nM
Compound 4: middle estimate off by 5.6-fold (0.74 log units), on the high side, and the stated range ends above it.
By their numbers in this assay, from the lowest: compounds 4, 1, 2 and 3 (each within the scatter of the next, the first and the last beyond it).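

In this assay, phenyl in place of methyl on the carbonyl carbon, on the double bond drawn Z, shows a 3.7-fold lower number from compound 3 to compound 4 (0.57 log units; beyond the scatter). This change does not carry over from one double-bond configuration to the other: the same change on two cores in this assay, a 1.8-fold higher number (0.25 log units; within the scatter) from compound 1 to compound 2 and a 3.7-fold lower number (0.57 log units; beyond the scatter) from compound 3 to compound 4, 6.6-fold (0.82 log units) apart, beyond the scatter of two such steps. The configuration itself also matters differently in the two esters, since the acetoxy pair shows a 2.1-fold higher number from compound 1 to compound 3 (0.32 log units; beyond the scatter), whereas the benzoyloxy pair shows a 3.1-fold lower number from compound 2 to compound 4 (0.50 log units; beyond the scatter), a step in the opposite direction: the fact that compounds 2 and 4 differ only in the configuration as drawn. Among these four compounds, the effect of the ester group therefore cannot be read without knowing the configuration, and the reverse also holds.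

The compounds shown leave open whether this dependence is particular to phenyl or also appears with another group on that carbonyl carbon, such as a longer chain or a cyclohexyl ring. They also give no explanation of why the two configurations respond differently.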